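The source may hold more compounds than are shown below. What is called first, only, known or untested is meant among the compounds shown, and "the series" means these compounds.

Measured compounds:
- compound 1, `CN(C)CCCCCCN(C)C1=Nc2ccccc2C(CC(=O)NCc2ccccc2)N1c1ccc(-c2ccccc2)cc1`, 550 nM
- compound 2, `CN(C)CCN1CCN(C2=Nc3ccccc3C(CC(=O)NCc3ccccc3)N2c2ccc(-c3ccccc3)cc2)CC1`, "not determined" (no result reported)
- compound 3, `Cc1ccc(CNC(=O)CC2c3ccccc3N=C(N3CCN(CCN(C)C)CC3)N2c2ccc(-c3ccccc3)cc2)cc1`, 460 nM

In an assay on HEK293 cells for inhibition of Voltage-dependent T-type calcium channel subunit alpha-1G (Homo sapiens), read by patch clamp (on this read-out higher numbers stand for weaker inhibition and lower numbers for stronger inhibition), compound 3 gives 460 nM, the lowest of the two numbers available. Compound 1 gives 550 nM in this assay, and the gap between these two values lies within the usual scatter, so the two cannot be told apart. For compound 2 no number was obtained in this assay.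

Compound 4, `CN(C)CCN1CCN(C2=Nc3ccccc3C(CC(=O)NCc3ccc(F)cc3)N2c2ccc(-c3ccccc3)cc2)CC1`, differs from compound 3 in a single place: fluoro in place of methyl on an aromatic carbon. Going by the values given here, the shared core and the amine-bearing side chain are unchanged, and no step between measured compounds shows what this exchange on the benzylamide ring does. With nothing in the data pointing either way, the step from compound 3 to compound 4 is expected to stay within the scatter, a 1.1-fold higher number from compound 3 to compound 4 (0.04 log units; within the scatter). For compound 4 the estimate in this assay is therefore 500 nM, with a plausible range from 200 nM to 1300 nM.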

Compound 4, half-maximal inhibitory concentration: 320 nM
Estimate against measurement, compound 4: 1.6-fold (0.19 log units) above; low and high end bracket the measured number.
By their numbers in this assay, from the lowest: compounds 4, 3 and 1 (each within the scatter of the next).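

In this assay the exchange of methyl for fluoro on this aromatic carbon, para to a large group, gives a 1.4-fold lower number from compound 3 to compound 4 (0.16 log units; within the scatter) and so stays inside the usual scatter. This single pair shows that, on the shared core with this amine-bearing side chain, the two groups cannot be told apart at this position, and compound 3 and compound 4 cannot be ranked. No measured property of either group is at hand that would bear on this result.

From the compounds shown here alone, what a chloro, a methoxy or a carboxylic acid on this same carbon would do remains open. So does whether the exchange of methyl for fluoro would read the same with a longer chain in place of the side chain of compound 4.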